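Methylsulfanyl in Place of Butyl on a Shared Core

The source may hold more compounds than are shown below. What is called first, only, known or untested is meant among the compounds shown, and "the series" means these compounds.

Measured compounds in an ADME assay on Vero cells (Chlorocebus sabaeus) for cytotoxicity, read by resazurin assay, with a stated time of 72 h; a lower number here means that less compound is tolerated, a higher number that more compound is tolerated:
- compound 1, `O=C(/C=C/c1ccc([N+](=O)[O-])s1)c1ccc(-n2ccnc2)cc1`, gives 42700 nM
- compound 2, `CC(C)(C)c1ccc(C(=O)/C=C/c2ccc([N+](=O)[O-])s2)cc1`, reaches only the limit > 100000 nM, a limit of the assay and not a number
- compound 3, `CCCCc1ccc(C(=O)/C=C/c2ccc([N+](=O)[O-])s2)cc1`, gives 81300 nM

Among the two numbers that are not limits, compound 3 stands highest, with compound 1 nearest: a 1.9-fold higher number from compound 1 to compound 3 (0.28 log units; within the scatter). The step of an at least 1.2-fold lower number from compound 2 to compound 3 (0.08 log units; that floor lies within the scatter) runs from a limit and says little. Compound 1 and compound 2 differ by an at least 2.3-fold higher number from compound 1 to compound 2 (0.36 log units; beyond the scatter), a step resting on (the limit of > 100000 nM in this assay, at which 1 of the 3 values shown sits).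

Compound 4, `CSc1ccc(C(=O)/C=C/c2ccc([N+](=O)[O-])s2)cc1`, has not been measured. It differs from compound 3 by methylsulfanyl in place of butyl on an aromatic carbon. Within the data shown here, no measured step exchanges a chain for methylsulfanyl, so the steps from compound 1 and compound 2 to compound 3 bear on it only loosely, and both show modest movement at most. Across all three measured compounds this assay has moved little whatever group occupies that position. The step of a 1.4-fold lower number from compound 3 to compound 4 (0.13 log units; within the scatter) is therefore expected to stay within the scatter. Compound 4 is estimated at 60000 nM, in a range from 25000 nM to 100000 nM, with a fair chance that only a limit is reported.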

Compound 4, half-maximal cytotoxic concentration: > 100000 nM
Compound 4: only a limit was reported; the forecaster's own chance of this, stated with the estimate: 30%; middle value at least 1.6-fold (0.22 log units) away from the limit.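

In this assay, compound 4 gives only a limit and not a number, which shows that this position, on an aromatic carbon para to a large group, can hold methylsulfanyl, with its sulfur and hydrogen-bond acceptor, and still reach the same limit as the purely carbon tert-butyl group: the limit of > 100000 nM in this assay, at which 2 of the 4 values shown sit. Against the butyl group the exchange shows no readable change, since the floor of an at least 1.2-fold higher number from compound 3 to compound 4 (0.08 log units; that floor lies within the scatter) lies within the scatter, whereas an at least 2.3-fold higher number from compound 1 to compound 4 (0.36 log units; beyond the scatter) is beyond the scatter and gives 1H-imidazol-1-yl a second such separation, after the one from tert-butyl. Compound 1 therefore stands apart from compound 2 and compound 4, but compound 3 goes against any clean split, as its step from compound 1 lies within the scatter, and the step between the two limits cannot be read.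

As far as these compounds go, how compound 2 and compound 4 compare remains unknown, as neither has a number in this assay. The compounds shown also leave open how an amine, a carboxylic acid or a longer chain at this position would read in this assay.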